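Benzyl ester at the ester position of the shared core

A few compounds are considered here, and "the series" means these few. Any claim that something is new, unique, unknown or untested is made for them only; others in the source may bear on it.

The compounds share one core and differ at the ester. Compound 1 `COC(=O)c1cccc(-c2cc(C(=O)Nc3ccncc3F)ccc2CN)c1` gives 7.8 nM in an assay on isolated protein for inhibition of Rho-associated protein kinase 2 (Homo sapiens), read by radiometric assay; a higher number here means a weaker inhibitor, a lower number a stronger inhibitor. Among the compounds with values here, compound 3 `NCc1ccc(C(=O)Nc2ccncc2F)cc1-c1cccc(C(=O)OCC2CC2)c1` gives 2.7 nM in this assay, and the step of a 2.9-fold lower number from compound 1 to compound 3 (0.46 log units; beyond the scatter) is the one measured change at this position. Compound 2 `CCOC(=O)c1cccc(-c2cc(C(=O)Nc3ccncc3)ccc2CN)c1` gives < 1 nM in this assay, which is a limit of the assay rather than a number (the limit of < 1 nM in this assay, at which 1 of the 3 values shown sits). Compound 4 `NCc1ccc(C(=O)Nc2ccncc2)cc1-c1cccc(C(=O)OCc2ccccc2)c1` differs from compound 2 by phenyl in place of methyl on a saturated chain carbon bound to an oxygen next to a carbonyl group. Given the step of a 2.9-fold lower number from compound 1 to compound 3 (0.46 log units; beyond the scatter), a larger group at this place is expected to hold or lower the number, so compound 4 is expected to sit at or past the limit as well. Compound 4 is estimated at 0.7 nM, between 0.2 nM and 3 nM. The expected step is a step that the limit leaves unreadable from compound 2 to compound 4.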

Compound 4, half-maximal inhibitory concentration: 45 nM
For compound 4 the middle estimate is 64-fold (1.81 log units) below the measured one; the measured number lies above the stated range.
By their numbers in this assay, from the lowest: compound 3; then compound 1; then compound 4. At a limit, below all of these: compound 2.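

Ethyl to benzyl at this position moves the number up, with an at least 45-fold higher number from compound 2 to compound 4 (1.65 log units; beyond the scatter) in this assay, whereas cyclopropyl in place of hydrogen gave a 2.9-fold lower number from compound 1 to compound 3 (0.46 log units; beyond the scatter). Adding carbon at this place therefore does not act in one direction: compound 4 goes against the lowering seen with compound 3. The step from ethyl is only a bound, because compound 2 stands at a limit: the limit of < 1 nM in this assay, at which 1 of the 4 values shown sits.

From the compounds shown here alone, whether a longer chain ending in phenyl, or a benzyl ring carrying an amine or a carboxylic acid, would follow benzyl stays open. The two steps also start from compounds that differ elsewhere in the core.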